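Bromo on the fused ring in two cores

The compounds below may be only part of what the source reports. "The series", "measured", "known", "first", "only" and "open" are said of these compounds alone.

Measured so far:
compound 1 `COc1ccc(C2=NN(C3=NC(=O)/C(=C4\C(=O)Nc5ccccc54)S3)C(c3ccc(OC)cc3)C2)cc1`: 100000 nM
compound 2 `COc1ccc(C2=NN(C3=NC(=O)/C(=C4\C(=O)Nc5ccc(Br)cc54)S3)C(c3ccc(OC)cc3)C2)cc1`: 380 nM
compound 3 `CN(C)c1ccc(C2CC(c3ccccc3)=NN2C2=NC(=O)/C(=C3\C(=O)Nc4ccccc43)S2)cc1`: 18800 nM

In a functional assay on cells (Cancer cell lines, Homo sapiens) for cytotoxicity, read by sulforhodamine B assay, with a stated time of 48 h (a higher number here means a weaker inhibitor of growth, a lower number a stronger inhibitor of growth), compound 1 gives 100000 nM and compound 2 gives 380 nM. For the measured compounds named here, the single change between them, (bromo in place of hydrogen on an aromatic carbon), produced a 260-fold lower number from compound 1 to compound 2 (2.42 log units; beyond the scatter). Compound 3 is built on a different core; the difference between the two cores is not broken down here. In this assay compound 3 gives 18800 nM.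

Compound 4 `CN(C)c1ccc(C2CC(c3ccccc3)=NN2C2=NC(=O)/C(=C3\C(=O)Nc4ccc(Br)cc43)S2)cc1` differs from compound 3 by bromo in place of hydrogen on an aromatic carbon, the same change that led from compound 1 to compound 2. Beside a 260-fold lower number from compound 1 to compound 2 (2.42 log units; beyond the scatter), the step from compound 3 to compound 4 is expected to be a 63-fold lower number from compound 3 to compound 4 (1.80 log units; beyond the scatter), somewhat smaller because it rests on a single precedent, a 260-fold lower number from compound 1 to compound 2 (2.42 log units; beyond the scatter), on another core. Compound 4 is therefore estimated at 300 nM in this assay, expected between 60 nM and 2000 nM.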

Compound 4, concentration for total growth inhibition: 450 nM
Compound 4: the middle estimate sits 1.5-fold (0.18 log units) below what was measured; measured number inside the range.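

In this assay, bromo in place of hydrogen on an aromatic carbon again gives a stronger inhibitor of growth on the second core, with a 42-fold lower number from compound 3 to compound 4 (1.62 log units; beyond the scatter). The direction of the change carries from one core to the other, but its size does not carry over unchanged: the same change on two cores in this assay, a 260-fold lower number (2.42 log units; beyond the scatter) from compound 1 to compound 2 and a 42-fold lower number (1.62 log units; beyond the scatter) from compound 3 to compound 4, 6.3-fold (0.80 log units) apart, beyond the scatter of two such steps. With one pair on each core, this shows neither why the size differs nor how the change would behave on a further core.

Whether the effect is particular to bromo remains open, since chloro, methyl, methoxy or an amine on the same aromatic carbon are not among the compounds shown. Also open, going by these compounds, is how the step would run with bromo on other aromatic carbons of the fused ring.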